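Chloro to hydrogen on the core of compound 3

A few compounds are considered here, and "the series" means these few. Any claim that something is new, unique, unknown or untested is made for them only; others in the source may bear on it.

Of the compounds shown here, three have been measured in a functional assay on DU-145 cells (Homo sapiens) for cytotoxicity, read by sulforhodamine B assay, with a stated time of 48 h; a higher number here means a weaker inhibitor of growth, a lower number a stronger inhibitor of growth. Compound 1 `Nc1nc(Cl)c2ncn(Cc3ccccc3CCl)c2n1` gives 14800 nM in this assay, and compound 2 `Nc1nc(Cl)c2ncn(Cc3ccc(CCl)cc3)c2n1` gives 6610 nM. Compound 3 `ClCc1cccc(Cn2cnc3nc(Cl)nc(Cl)c32)c1`, which carries two chloro groups on its core and a chloromethyl on the benzyl ring, gives 140 nM, the lowest of the three numbers; its gaps to compound 2 and to compound 1 are both beyond the scatter, so compound 3 is the strongest inhibitor of growth among those measured. Among the measured compounds shown here, no pair of measured compounds differs in only one place, so no single-change step is available as a guide.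

Compound 4 `ClCc1cccc(Cn2cnc3ncnc(Cl)c32)c1` has not yet been measured. It differs from compound 3 as follows: hydrogen in place of chloro on an aromatic carbon

With no measured step of this kind in the series, the expected direction rests only on the place of the change: hydrogen in place of chloro on an aromatic carbon of the core. A modest loss of potency is expected, of a size that may or may not exceed the scatter, so the step from compound 3 to compound 4 is estimated as a 2.9-fold higher number from compound 3 to compound 4 (0.46 log units; beyond the scatter). Compound 4 is therefore expected to give about 400 nM in this assay, with a range from 100 nM to 2000 nM.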

Compound 4, concentration for 50% growth inhibition: 15100 nM
Estimate against measurement, compound 4: 38-fold (1.58 log units) below; measured number outside the range, above it.
By their numbers in this assay, from the lowest: compound 3; then compound 2; then compounds 1 and 4 (each within the scatter of the next).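

Chloro on the aromatic carbon between two ring nitrogen atoms is a major contributor to the low number of compound 3: hydrogen in its place gives a 110-fold higher number from compound 3 to compound 4 (2.03 log units; beyond the scatter) in this assay and is the first single-change step available in the series. The change removes only one heavy atom and leaves the rest of the structure untouched, so this position is highly sensitive to the change from chloro to hydrogen. The chloro group meta to this position and the chloromethyl on the benzyl ring are both still present in compound 4, yet compound 4 gives 15100 nM in this test, so those two groups do not preserve the low number of compound 3 on their own.

No measurement on hand explains why this one replacement has so large an effect.

On these data alone, whether the position depends on chloro itself remains open, since a single step cannot separate chloro from other groups such as bromo, fluoro or methoxy on the same carbon. As far as these compounds go, it is also open whether the second chloro on the core, or the chloromethyl on the benzyl ring, would show a step of similar size if replaced by hydrogen.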